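The compounds below may be only part of what the source reports. "The series", "measured", "known", "first", "only" and "open" are said of these compounds alone.

Compound 1 `O=C1C(Nc2ccccc2F)=CC(=O)c2c1nc1n2[C@H]2OC[C@@H](O)[C@H]2OC1`: 2000 nM
Compound 2 `O=C1C=C(NC2CCCCC2)C(=O)c2c1nc1n2[C@H]2OC[C@@H](O)[C@H]2OC1`: > 8000 nM (a limit)

Both compounds were tested in a functional assay on MGC-803 cells (Homo sapiens) for inhibition, read by sulforhodamine B assay; on this read-out lower numbers stand for stronger inhibition and higher numbers for weaker inhibition. Within the data shown here, compound 1 gives 2000 nM, the only true number available, so it is the single firm reference point. Compound 2 gives > 8000 nM, which is a limit of the assay and not a number.

The next compound to be tested is compound 3 `O=C1C(N2CCCC2)=CC(=O)c2c1nc1n2[C@H]2OC[C@@H](O)[C@H]2OC1`. It keeps the core of compound 1 but carries pyrrolidin-1-yl in place of (2-fluorophenyl)amino on a double-bonded ring carbon. Among the measured compounds shown here, no measured step between compounds that differ in one place exists here, so the size of this change cannot be read directly from the data.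

A modest move toward weaker inhibition in this assay seems the most likely outcome, though an outcome within the usual scatter would be no surprise. This leaning rests only on compound 2, whose result is the limit > 8000 nM. The expected change is a 2.0-fold higher number from compound 1 to compound 3 (0.30 log units; within the scatter), and it is an uncertain estimate. For compound 3 the estimated value is 4000 nM, with an expected range from 1000 nM to 12000 nM.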

Compound 3, half-maximal inhibitory concentration: > 16000 nM
Compound 3 was reported as a limit; the forecaster's own chance of this, stated with the estimate: 30%; middle value at least 4.0-fold (0.60 log units) from the limit.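

In this assay, among these compounds, this pair gives the first direct reading of a single change on this double-bonded ring carbon: pyrrolidin-1-yl in place of (2-fluorophenyl)amino gives an at least 8.0-fold higher number from compound 1 to compound 3 (0.90 log units; beyond the scatter), so what sits at this position clearly matters. Compound 3 gives > 16000 nM, which is a limit of the assay and not a number, so this step shows only the least possible loss of inhibition and not its full size: the limit of > 16000 nM in this assay, at which 1 of the 3 values shown sits.

The change also does several things at once, swapping a six-membered aromatic ring of carbon only for a five-membered non-aromatic ring and leaving the group without a hydrogen-bond donor, and this one pair cannot separate those differences.

From the compounds shown here alone, it therefore stays open whether the aromatic ring, the amine hydrogen or the fluorine accounts for the inhibition seen with compound 1. A phenoxy group would keep the aromatic ring without the amine hydrogen, a cyclopentylamino group would keep the amine hydrogen without the aromatic ring, and a plain phenylamino group would test the fluorine alone, so each would pull apart one of these questions.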